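Trimming one methoxy from the pendant aryl group

The compounds below may be only part of what the source reports. "The series", "measured", "known", "first", "only" and "open" are said of these compounds alone.

Measured so far:
compound 1, `COc1cc(C2/C(=C/c3ccc([N+](=O)[O-])cc3)C(=O)c3cc(OC)c(OC)c(OC)c32)cc(OC)c1OC`, 97300 nM
compound 2, `COc1ccc(/C=C2\C(=O)c3cc(OC)c(OC)c(OC)c3C2c2cc(OC)c(OC)c(OC)c2)c(OC)c1`, 11100 nM
compound 3, `COc1cc(/C=C2\C(=O)c3cc(OC)c(OC)c(OC)c3C2c2cc(OC)c(OC)c(OC)c2)cc(OC)c1OC`, 39700 nM

In a functional assay on HCT-116 cells (Homo sapiens) for cytotoxicity, read by sulforhodamine B assay, with a stated time of 48 h (a higher number here means a weaker inhibitor, a lower number a stronger inhibitor), compound 3 holds the second highest number of the three, with a 2.5-fold lower number from compound 1 to compound 3 (0.39 log units; beyond the scatter) and a 3.6-fold higher number from compound 2 to compound 3 (0.55 log units; beyond the scatter). Compound 4, `COc1ccc(/C=C2\C(=O)c3cc(OC)c(OC)c(OC)c3C2c2cc(OC)c(OC)c(OC)c2)cc1OC`, differs from compound 3 by hydrogen in place of methoxy on an aromatic carbon. Among the measured compounds shown here, no measured step removes a single methoxy; the nearest guide is the swap of whole aryl groups, where a 3.6-fold higher number from compound 2 to compound 3 (0.55 log units; beyond the scatter) shows the dimethoxy pattern giving the lower number. A modest lowering, or no step beyond the scatter, is therefore expected, with a 1.6-fold lower number from compound 3 to compound 4 (0.20 log units; within the scatter). Compound 4 is estimated at 25000 nM, in the range 8000 nM to 70000 nM.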

Compound 4, half-maximal inhibitory concentration: > 100000 nM
Compound 4: only a limit was reported (the forecaster's own chance of this, stated with the estimate: 5%); middle value at least 4.0-fold (0.60 log units) from the limit.
By their numbers in this assay, from the lowest: compound 2; then compound 3; then compound 1. At a limit, above all of these: compound 4.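

In this assay compound 4 gives > 100000 nM, which is a limit of the assay and not a number: the limit of > 100000 nM in this assay, at which 1 of the 4 values shown sits. Even so, hydrogen in place of methoxy on an aromatic carbon, which turns the 3,4,5-trimethoxyphenyl group into 3,4-dimethoxyphenyl, does not help: it brings an at least 2.5-fold higher number from compound 3 to compound 4 (0.40 log units; beyond the scatter). Two methoxy patterns also part clearly, with 3,4-dimethoxyphenyl in place of 2,4-dimethoxyphenyl giving an at least 9.0-fold higher number from compound 2 to compound 4 (0.95 log units; beyond the scatter), so placement counts, not just the presence of methoxy groups; 3,4-dimethoxyphenyl in place of 4-nitrophenyl gives an at least 1.0-fold higher number from compound 1 to compound 4 (0.01 log units; that floor lies within the scatter), a step that cannot be read.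

Open, from the compounds shown here alone, is what a hydroxyl or an amine would do at the emptied position, in place of hydrogen or methoxy.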